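The source may report more compounds than this note shows. Statements on the series, on what has been measured and on what is new or still open speak of the compounds shown alone.

Measured so far in an assay on isolated protein for inhibition of Amine oxidase [flavin-containing] A (Homo sapiens), read by fluorescence and Amplex Red, with a stated time of 30 min, tested at 0.01 nM; a lower number here means a weaker effect, a higher number a stronger effect of the compound at the concentration tested:

- compound 1 `CCCCNc1nnc(SCC(=O)N(Cc2cccc([N+](=O)[O-])c2)c2ccc(F)cc2)s1`, 6.94%
- compound 2 `CCCNc1nnc(SCC(=O)N(Cc2cccc([N+](=O)[O-])c2)c2ccc(F)cc2)s1`, 8.5%
- compound 3 `CC(C)CNc1nnc(SCC(=O)N(Cc2cccc([N+](=O)[O-])c2)c2ccc(F)cc2)s1`, 6.36%

All three numbers sit close together at the low end of the read-out. Compound 3 holds the lowest of the three, but the steps leading to it are small: a number 0.6 percentage points lower from compound 1 to compound 3 (within the scatter) and a number 2.1 percentage points lower from compound 2 to compound 3 (within the scatter); both steps are within the scatter, so no order among the three can be read from them. The remaining pair, a number 1.6 percentage points higher from compound 1 to compound 2 (within the scatter), is also within the scatter.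

Compound 4 `COCCNc1nnc(SCC(=O)N(Cc2cccc([N+](=O)[O-])c2)c2ccc(F)cc2)s1` is the next point. Against compound 3 the change is methoxymethyl in place of isopropyl on a saturated chain carbon bound to a nitrogen on an aromatic ring. Among the compounds with values here, the steps that bear on it are those at the same place, from compound 1 to compound 3 and from compound 2 to compound 3, where swapping one small alkyl chain for another moved nothing beyond the scatter. Within the data shown here, the entering group carries one hydrogen-bond acceptor where the leaving one has none, and no measured step covers that, so the expectation rests only on the flat behaviour seen across the three chains.

Compound 4 is therefore expected to show a number 1.1 percentage points higher from compound 3 to compound 4 (within the scatter), nothing beyond the scatter. The estimate for compound 4 in this assay is 7.5%, ranging from 0% to 16%.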

Compound 4, a percentage reported as inhibition, at one concentration (the size of the read-out at that concentration, not a potency): 13.5%
Estimate against measurement, compound 4: 6 percentage points below; low and high end bracket the measured number.
By their numbers in this assay, from the lowest: compounds 3, 1, 2 and 4 (each within the scatter of the next).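

In this assay, putting methoxymethyl in place of isopropyl on a saturated chain carbon bound to a nitrogen on an aromatic ring gives a number 7.1 percentage points higher from compound 3 to compound 4 (within the scatter), while the two related changes that bring in the methoxy give a number 5 percentage points higher from compound 2 to compound 4 (within the scatter) and a number 6.6 percentage points higher from compound 1 to compound 4 (within the scatter). Within the data shown here, the position therefore stays flat beyond the plain alkyl chains: the 2-methoxyethyl chain, the first here with a hydrogen-bond acceptor, stays within the scatter of the propyl, butyl and isobutyl chains, although these three steps are larger in size than any among the earlier compounds, so no gain can be claimed for the ether oxygen. Nothing available on these compounds bears on this result or accounts for the size of these steps.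

Still open, going by these compounds, is whether a terminal amine, a carboxylic acid or a longer ether chain at this place would move the read-out beyond the scatter. All the compounds shown also share the rest of the structure and are read at one concentration, so neither the role of the other parts of the core nor any potency can be taken from them.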